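The source may report more compounds than this note shows. Statements on the series, on what has been measured and on what is new or still open speak of the compounds shown alone.

Compound 1 `Cc1ccc(S(=O)(=O)NCc2ccc(CNC(=O)c3ccc([N+](=O)[O-])cc3)cc2)cc1` carries a 4-nitrophenyl group on its carbonyl carbon. In an assay on MDA-MB-231 cells for binding affinity to C-X-C chemokine receptor type 4 (Homo sapiens), read by immunofluorescence and microscopy, with stated times of 10 min and 30 min (a lower number here means that less compound is needed, a higher number that more compound is needed for the effect), compound 1 gives 10 nM. Compound 2 `O=C(NCc1ccc(CNS(=O)(=O)c2ccccc2)cc1)c1cccnc1`, which has a pyridin-3-yl group at the same place, gives 10 nM in this assay, so compound 1 and compound 2 stand level at the digits shown and are together the lowest of the three numbers. Going by the values given here, compound 3 `Cc1cccc(C(=O)NCc2ccc(CNS(=O)(=O)c3ccccc3)cc2)c1` gives 1000 nM, and the single measured step, a 100-fold higher number from compound 2 to compound 3 (2.00 log units; beyond the scatter), shows that exchanging the group on the carbonyl carbon can move the number a long way.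

Compound 4 `Cc1ccc(S(=O)(=O)NCc2ccc(CNC(=O)c3cccc(F)c3)cc2)cc1` differs from compound 1 only there: 3-fluorophenyl in place of 4-nitrophenyl on a carbonyl carbon. Among the compounds with values here, the one step that bears on this is a 100-fold higher number from compound 2 to compound 3 (2.00 log units; beyond the scatter), since it also replaces the ring on the carbonyl carbon with a phenyl ring that carries a small substituent, and the new ring of compound 4 is of the same kind. On that basis a step upward, beyond the scatter but perhaps smaller than the measured one, is expected in this assay, namely a 30-fold higher number from compound 1 to compound 4 (1.48 log units; beyond the scatter). Compound 4 is therefore estimated to give 300 nM in this assay, with the expected range running from 30 nM to 3000 nM.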

Compound 4, effective concentration (reported as EC, without a stated level of effect): 1 nM
Compound 4: middle estimate off by 300-fold (2.48 log units), on the high side; measured number below the stated range.
By their numbers in this assay, from the lowest: compound 4; then compounds 1 and 2 (each within the scatter of the next); then compound 3.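

In this assay the exchange of 4-nitrophenyl for 3-fluorophenyl on the carbonyl carbon gives a 10-fold lower number from compound 1 to compound 4 (1.00 log units; beyond the scatter) and so shows that the 4-nitrophenyl group is not needed for a low number, even though the entering group counts 0 hydrogen-bond acceptors against 2 for the group that leaves. Taken with a 100-fold higher number from compound 2 to compound 3 (2.00 log units; beyond the scatter) this means that changes at this one place can move the number in either direction, so a carbon-only aromatic ring on the carbonyl carbon does not by itself bring a rise, although these two steps start from compounds that also differ elsewhere in the core. Nothing available explains why the number fell here.

A plain phenyl group at this place on the core of compound 1 would help to separate what the loss of the nitro group does from what the arrival of the fluorine does. As far as these compounds go, how an amine or a carboxylic acid on this ring would behave remains open, as does whether 3-fluorophenyl would give the same kind of step on the core of compound 2.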